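A few compounds are considered here, and "the series" means these few. Any claim that something is new, unique, unknown or untested is made for them only; others in the source may bear on it.

Three compounds have been measured in a functional assay on DU-145 cells (Homo sapiens) for inhibition, read by trypan blue exclusion, with a stated time of 96 h; a higher number here means a weaker inhibitor of growth, a lower number a stronger inhibitor of growth:

Compound 1, `Cc1ccc(CS(=O)(=O)/C(=C/c2cccc(Cl)c2Cl)C(=O)c2ccc(Cl)cc2)cc1`, gives 1000 nM.
Compound 2, `O=C(/C(=C\c1ccc(OCc2ccccc2)cc1)S(=O)(=O)Cc1ccc(Cl)cc1)c1ccc(Cl)cc1`, gives 1000 nM.
Compound 3, `COc1ccc(C(=O)/C(=C\c2ccc(Cl)cc2)Sc2ccc(F)cc2)cc1`, gives > 100000 nM, which is a limit of the assay and not a number.

On these numbers compound 1 stands level with compound 2 at the digits shown; the two values lie within the usual scatter of each other, so no order between them can be read. Compound 3 sits at the limit of > 100000 nM in this assay, at which 1 of the 3 values shown sits. For the measured compounds named here, compound 3 differs from compound 1 in more than one place, so no single step can be drawn between them; its limit says only that in this assay it falls far from compound 1 and compound 2.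

The step to compound 4, `Cc1ccc(CS(=O)(=O)/C(=C/c2ccc(C)s2)C(=O)c2ccc(Cl)cc2)cc1`, is a single change on the shared core of compound 1: 5-methylthiophen-2-yl in place of 2,3-dichlorophenyl on a double-bonded chain carbon bound to a double-bonded chain carbon. Going by the values given here, no measured pair shows a step of this kind, and compound 2 shows that a different group at this place left the value of compound 1 unchanged within the scatter. On that basis the step of a 2.0-fold higher number from compound 1 to compound 4 (0.30 log units; within the scatter) is expected to be small, leaning if anything toward a weaker inhibitor of growth, and it may not clear the scatter. Compound 4 is therefore estimated at 2000 nM, within a range from 500 nM to 10000 nM.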

Compound 4, concentration for 50% growth inhibition: 25000 nM
Compound 4: middle estimate off by 13-fold (1.10 log units), on the low side, and the stated range ends below it.
By their numbers in this assay, from the lowest: compounds 1 and 2 (each within the scatter of the next); then compound 4. At a limit, above all of these: compound 3.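

In this assay, putting 5-methylthiophen-2-yl in place of 2,3-dichlorophenyl on a double-bonded chain carbon bound to a double-bonded chain carbon gives a 25-fold higher number from compound 1 to compound 4 (1.40 log units; beyond the scatter) and so makes compound 4 a clearly weaker inhibitor of growth than compound 1. For the compounds shown here, no earlier pair differed in one place only, so this is the first direct reading of this position, and it shows that the group held here can move the value well beyond the scatter on the core of compound 1. Nothing measured here explains the size of this step.

The change replaces a six-membered ring of carbon only with a five-membered ring holding one hetero atom and also exchanges two chlorine atoms for one methyl group, so the compounds shown leave open whether the ring, its substituents or both account for the step. A 5-chlorothiophen-2-yl group or a 4-methylphenyl group at this place would separate these two parts of the change, and a single pair cannot show whether the same step would hold on another core.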